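This account rests on a few compounds, and the source may have more. Where it says the series, first, only, none or still open, it means among the compounds named here.

Compound 1, `CCCCCCCCCCC[C@@H](C[C@@H]1OC(=O)[C@H]1CCCCCC)OC(=O)[C@H](CC(C)C)NC(=O)OC(C)(C)C`. In an assay on membranes from brain for inhibition of Fatty-acid amide hydrolase 1 (Rattus norvegicus) (on this read-out higher numbers stand for weaker inhibition and lower numbers for stronger inhibition), compound 1 gives > 50000 nM, which is a limit of the assay and not a number.
Compound 2, `CCCCCCCCCCC[C@@H](C[C@@H]1OC(=O)[C@H]1CCCCCC)OC(=O)[C@@H](N)CC(C)C`. In this assay compound 2 gives > 50000 nM, again a limit of the assay.
Compound 3, `CCCCCCCCCCC[C@@H](C[C@@H]1OC(=O)[C@H]1CCCCCC)OC(=O)CCC(C)C`. In this assay compound 3 gives 10400 nM.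

Going by the values given here, compound 3 therefore holds the only actual number in this set; the other two values sit at the limit of > 50000 nM in this assay, at which 2 of the 3 values shown sit.

Compound 4, `CCCCCCCCCCC[C@@H](C[C@@H]1OC(=O)[C@H]1CCCCCC)OC(=O)CNC(=O)OCc1ccccc1`, differs from compound 3 by (benzyloxycarbonyl)amino in place of isobutyl on a saturated chain carbon bound to a carbonyl carbon. Among the compounds with values here, two measured steps bear on this change. Removing a nitrogen substituent from the saturated chain carbon bound to the carbonyl carbon gave an at least 4.8-fold lower number from compound 1 to compound 3 (0.68 log units; beyond the scatter) and likewise an at least 4.8-fold lower number from compound 2 to compound 3 (0.68 log units; beyond the scatter). Compound 4 runs in the opposite direction: a protected nitrogen is introduced on such a carbon, while the branched isobutyl of compound 3 is lost. Compound 4 is therefore expected to show a weaker inhibition, with a 3.8-fold higher number from compound 3 to compound 4 (0.59 log units; beyond the scatter) as a clearly higher number, quite possibly reported only as a limit. The estimate for compound 4 is 40000 nM, within a range from 12000 nM to 150000 nM.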

Compound 4, half-maximal inhibitory concentration: > 50000 nM
Compound 4: only a limit was reported; the forecaster's own chance of this, stated with the estimate: 55%; middle value at least 1.2-fold (0.09 log units) from the limit.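

In this assay, (benzyloxycarbonyl)amino in place of isobutyl gives an at least 4.8-fold higher number from compound 3 to compound 4 (0.68 log units; beyond the scatter), so the higher number seen with a nitrogen-bearing group on this saturated chain carbon bound to a carbonyl carbon also appears when isobutyl is gone and an aromatic ring enters. Compound 4 gives > 50000 nM, which is a limit of the assay. The step from compound 2 to compound 4 cannot be read, and most of the set now stands at one limit: the limit of > 50000 nM in this assay, at which 3 of the 4 values shown sit.

The compounds shown leave open whether the loss of isobutyl or the entry of the carbamate nitrogen accounts for the step, as compound 4 changes both together. Also open, on these data alone, is how a plain benzyl group, a longer chain or a carboxylic acid at this place would read out.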